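The compounds below may be only part of what the source reports. "The series", "measured", "known", "first", "only" and "open" are said of these compounds alone.

Measured so far in an assay on isolated protein for agonist activity at Bile acid receptor (Homo sapiens), read by AlphaScreen, with a stated time of 30 min; a higher number here means that more compound is needed for the effect, a lower number that less compound is needed:
compound 1 `Cc1ccccc1-n1nc(C)c2c1NC(=O)[C@H](C)S[C@@H]2c1ccc(Oc2ccccc2)cc1` gives 1300 nM
compound 2 `COc1cc([C@H]2S[C@@H](C)C(=O)Nc3c2c(C)nn3-c2ccccc2C)ccc1Oc1ccccc1` gives 1900 nM

For the measured compounds named here, compound 1 holds the lowest of the two numbers, but its only neighbour is close: the step of a 1.5-fold higher number from compound 1 to compound 2 (0.16 log units; within the scatter) stays within the scatter of repeated measurements, so the two compounds cannot be told apart in this assay.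

Compound 3 `Cc1ccccc1-n1nc(C)c2c1NC(=O)[C@H](C)S[C@@H]2c1ccc(Oc2cccc(C(=O)O)c2)cc1` differs from compound 1 in a single place: carboxy in place of hydrogen on an aromatic carbon. Going by the values given here, the one measured step, from compound 1 to compound 2, concerns a different position and a different entering group, methoxy in place of hydrogen, and it did not move the number beyond the scatter. Among the compounds with values here, no measured step touches the phenoxy ring or a carboxy group, so nothing here speaks directly for or against this change. The expectation therefore rests on the starting point alone, and the expected step is a 1.3-fold lower number from compound 1 to compound 3 (0.11 log units; within the scatter), which means no change beyond the scatter is expected, with a wide range to cover the lack of a guiding step.

For compound 3 the estimate in this assay is 1000 nM, ranging from 250 nM to 4000 nM.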

Compound 3, half-maximal effective concentration: "not active" (no number reported)
No number was reported for compound 3; there is nothing to compare the estimate with.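

In this assay, for the compounds shown here, compound 3 is recorded as "not active" with no number, so no step from compound 1 to compound 3 can be read. Open, going by these compounds, is whether any other group at that place on the phenoxy ring would give a number comparable to that of compound 1, 1300 nM. Nothing available bears on this result.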